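The compounds below may be only part of what the source reports. "The series", "measured", "known", "first", "only" and "open" are said of these compounds alone.

Compound 1 `Cn1cc(C2=C(c3nn(CCCn4ccnc4)c4ncccc34)C(=O)N(c3ccccc3)C2=O)c2ccccc21` is the parent of this small set. Among the measured compounds shown here, in a functional assay on ECa-109 cells (Homo sapiens) for antiproliferative activity, read by MTT assay, with a stated time of 48 h (a higher number here means a weaker inhibitor, a lower number a stronger inhibitor), compound 1 gives 1440 nM, the only full number among the three measured compounds. Compound 2 `Cn1cc(C2=C(c3nn(CCCn4ccnc4)c4ncccc34)C(=O)NC2=O)c2ccccc21` carries hydrogen in place of phenyl on an amide-type nitrogen in a ring, and in this assay compound 2 returns only a limit, > 100000 nM. Compound 3 `Cn1cc(C2=C(c3nn(CCCn4cccc4)c4ncccc34)C(=O)NC2=O)c2ccccc21` likewise returns only a limit in this assay, > 100000 nM. The step of an at least 69-fold higher number from compound 1 to compound 2 (1.84 log units; beyond the scatter) is thus large, whereas a step that the two limits leave unreadable from compound 2 to compound 3 cannot be sized. Compound 4 `Cn1cc(C2=C(c3nn(CCCn4cncn4)c4ncccc34)C(=O)N(c3ccccc3)C2=O)c2ccccc21` keeps the phenyl of compound 1 and alters only the group on the saturated chain carbon: 1H-1,2,4-triazol-1-yl in place of 1H-imidazol-1-yl on a saturated chain carbon, three bonds along the chain from an aromatic nitrogen. For the measured compounds named here, no measured step reports on this exchange with a readable size, so no shift beyond the scatter is expected in this assay, with a 1.4-fold higher number from compound 1 to compound 4 (0.14 log units; within the scatter). Compound 4 is therefore estimated at 2000 nM, between 700 nM and 6000 nM.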

Compound 4, half-maximal inhibitory concentration: > 100000 nM
Compound 4 gave a limit, no number (the forecaster's own chance of this, stated with the estimate: 5%); at least 50-fold (1.69 log units) between middle value and limit.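

In this assay, the end of the chain proves sensitive once the phenyl of compound 1 is kept: an at least 69-fold higher number from compound 1 to compound 4 (1.84 log units; beyond the scatter). Compound 2 had already shown a step of this kind at the amide-type nitrogen, and this is the first readable step at the chain end. The step gives only a minimum size, as compound 4 returns a limit and not a number: the limit of > 100000 nM in this assay, at which 3 of the 4 values shown sit.

Still open, from the compounds shown here alone, is how a dimethylamino group or a longer chain carrying the 1H-imidazol-1-yl group would fare in this position. A benzyl group in place of the phenyl also remains untested among the compounds shown.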